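A few compounds are considered here, and "the series" means these few. Any claim that something is new, unique, unknown or untested is made for them only; others in the source may bear on it.

Compound 1 `CCOc1cc2nnc(C(N)=O)c(Nc3cccc(Cl)c3F)c2cc1N1CCN(C)CC1` gives 18000 nM in a physicochemical assay for solubility; on this read-out higher numbers stand for higher solubility and lower numbers for lower solubility. Compound 2 `COc1cc2nnc(C(N)=O)c(Nc3ccc(C)cc3F)c2cc1N1CCN(C)CC1` gives 87000 nM. Compound 3 `COc1cc2nnc(C(N)=O)c(Nc3cc(C)ccc3F)c2cc1N1CCN(C)CC1` gives 22000 nM.

Compound 3 stands second highest of the three numbers in this assay. Its nearest neighbour is compound 1, within the scatter of it, while compound 2 sits clearly higher. The one step that has been measured between two of these compounds is a 4.0-fold lower number from compound 2 to compound 3 (0.60 log units; beyond the scatter), a modest change that came from moving a methyl group on the aryl ring attached to the nitrogen.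

Compound 4 `COc1cc2nnc(C(N)=O)c(Nc3cccc(Cl)c3F)c2cc1N1CCN(C)CC1` has not been measured. The change from compound 3 is 3-chloro-2-fluorophenyl in place of 2-fluoro-5-methylphenyl on a nitrogen on an aromatic ring. For the measured compounds named here, no measured step makes exactly this swap, so the expectation rests on what the numbers show: compound 1, which also carries a 3-chloro-2-fluorophenyl group, gives a number within the scatter of compound 3. For compound 4 the step from compound 3 is therefore expected to be a 1.2-fold lower number from compound 3 to compound 4 (0.09 log units; within the scatter), that is no shift beyond the scatter. The estimate for compound 4 is 18000 nM, with a range from 7000 nM to 45000 nM.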

Compound 4, solubility: 110000 nM
Estimate against measurement, compound 4: 6.1-fold (0.79 log units) below, and the stated range ends below it.
By their numbers in this assay, from the lowest: compounds 1 and 3 (each within the scatter of the next); then compounds 2 and 4 (each within the scatter of the next).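

In this assay, the 3-chloro-2-fluorophenyl group does not go with a low number on its own: with this group unchanged, hydrogen in place of methyl on a saturated chain carbon bound to an oxygen on an aromatic ring gives a 6.1-fold higher number from compound 1 to compound 4 (0.79 log units; beyond the scatter), so that second place also moves the read-out. The same group entering on the nitrogen gives a 5.0-fold higher number from compound 3 to compound 4 (0.70 log units; beyond the scatter) when it replaces 2-fluoro-5-methylphenyl, but a 1.3-fold higher number from compound 2 to compound 4 (0.10 log units; within the scatter) when it replaces 2-fluoro-4-methylphenyl, so the size of the step depends on which group leaves. Nothing available here explains either shift.

From the compounds shown here alone, whether the change on the oxygen-bound chain has a similar effect with the two methyl-bearing aryl groups remains open. So does the outcome of a longer chain such as propyl at that place, or of a nitrile on the aryl ring.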